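Amine chain swap on an antiproliferative chromone scaffold

The compounds below may be only part of what the source reports. "The series", "measured", "known", "first", "only" and "open" are said of these compounds alone.

Compound 2 `COc1cc(OC)c2c(=O)cc(-c3ccc(OCCCN)cc3)oc2c1` gives 39% in a functional assay (Homo sapiens) for antiproliferative activity, read by resazurin assay, with a stated time of 48 h, tested at 10 uM (on this read-out higher numbers stand for a stronger effect at the one concentration tested and lower numbers for a weaker effect), the higher of the two numbers measured; compound 1 `COc1cc(OC)c2c(=O)cc(-c3ccc(OCCN4CCCC4=O)cc3)oc2c1` gives 14% in this assay. Going by the values given here, the one measured step, a number 25 percentage points higher from compound 1 to compound 2 (beyond the scatter), concerns the end of the chain. Compound 3 `COc1cc(OC)c2c(=O)cc(-c3ccc(NCCN4CCCC4)cc3)oc2c1` differs from compound 2 as follows: (2-(pyrrolidin-1-yl)ethyl)amino in place of 3-aminopropoxy on an aromatic carbon. Among the compounds with values here, no measured step covers the amino linkage, and the ring that enters is not the one that left in compound 1, so the step of a number 25 percentage points higher from compound 1 to compound 2 (beyond the scatter) bears only loosely on this change. Compound 3 is therefore expected to give 30% (range 10% to 55%), an estimated step of a number 9 percentage points lower from compound 2 to compound 3 (within the scatter) in this assay, with no direction beyond the scatter confidently expected.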

Compound 3, a percentage reported as inhibition, at one concentration (the size of the read-out at that concentration, not a potency): 51%
Compound 3: middle estimate off by 21 percentage points, on the low side; low and high end bracket the measured number.
By their numbers in this assay, from the lowest: compound 1; then compound 2; then compound 3.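

Going by these compounds alone, at the aromatic carbon para to a large group, (2-(pyrrolidin-1-yl)ethyl)amino in place of 3-aminopropoxy gives a number 12 percentage points higher from compound 2 to compound 3 (beyond the scatter) in this assay, so the highest number so far comes with a chain joined through nitrogen rather than oxygen. Set against 2-(2-oxopyrrolidin-1-yl)ethoxy, the same group gives a number 37 percentage points higher from compound 1 to compound 3 (beyond the scatter). Nothing available explains these steps.

The linking atom and the chain end change together here, so their contributions stay unseparated. The 2-(pyrrolidin-1-yl)ethoxy chain, or a piperidine ring at the chain end, would bear on this.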